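Alkyne substituent series: octyl in place of cyclopropyl

The compounds below may be only part of what the source reports. "The series", "measured", "known", "first", "only" and "open" are said of these compounds alone.

The three measured compounds share one core and differ only in the group on the triple-bonded carbon. Compound 1 `O=c1[nH]c(=O)n(CCC(CO)CO)cc1C#Cc1ccc(Br)cc1` carries 4-bromophenyl there. In a functional assay on SW-620 cells (Homo sapiens) for antiproliferative activity, read by MTT assay, with a stated time of 72 h (a higher number here means a weaker inhibitor, a lower number a stronger inhibitor), compound 1 gives only a limit, > 100000 nM. Compound 2 `O=c1[nH]c(=O)n(CCC(CO)CO)cc1C#CCc1ccccc1` carries benzyl; in this assay compound 2 gives 72400 nM. Compound 3 `O=c1[nH]c(=O)n(CCC(CO)CO)cc1C#CC1CC1` carries cyclopropyl. In this assay compound 3 gives a limit, > 100000 nM. Compound 3 therefore stands at the limit of > 100000 nM in this assay, at which 2 of the 3 values shown sit. The step of an at least 1.3-fold higher number from compound 2 to compound 3 (0.14 log units; that floor lies within the scatter) is readable only as a floor, the step that the two limits leave unreadable from compound 1 to compound 3 is not readable at all, and the step of an at least 1.3-fold lower number from compound 1 to compound 2 (0.14 log units; that floor lies within the scatter) is again only a floor.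

Compound 4 `CCCCCCCCC#Cc1cn(CCC(CO)CO)c(=O)[nH]c1=O` differs from compound 3 by octyl in place of cyclopropyl on a triple-bonded carbon. Among the compounds with values here, the steps that bear on it are the two steps into compound 3, both resting on a limit, and neither shows a change beyond the scatter. Within the data shown here, no measured step involves an open chain of this kind. Accordingly no step beyond the scatter is expected in this assay, in either direction. Compound 4 is expected to give 90000 nM, with a range from 25000 nM to 300000 nM. The expected step is then an at least 1.1-fold lower number from compound 3 to compound 4 (0.04 log units; that floor lies within the scatter), with a fair chance that only a limit is reported again.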

Compound 4, half-maximal inhibitory concentration: > 100000 nM
Compound 4: a limit, no number; the forecaster's own chance of this, stated with the estimate: 55%; middle value at least 1.1-fold (0.04 log units) from the limit.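

Octyl is the first open chain at this position, and in this assay compound 4 gives only a limit, so a ring on the triple-bonded carbon is not needed for a result of this kind: the limit of > 100000 nM in this assay, at which 3 of the 4 values shown sit. Within the data shown here, the one readable step, an at least 1.3-fold higher number from compound 2 to compound 4 (0.14 log units; that floor lies within the scatter), is a floor, and it gives no size for heptyl in place of phenyl on a saturated chain carbon bound to a triple-bonded carbon. Among these compounds, the steps from compound 1 and from compound 3 to compound 4 cannot be read, which leaves compound 2 as the only compound with a number rather than a limit.

How far compound 1, compound 3 and compound 4 lie from one another cannot be told from these limits, and no group shown at this position gives a step beyond the scatter. On these data alone, whether a shorter chain, or a chain ending in an amine or a carboxylic acid, would give a number in this assay stays open.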